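From 2-bromophenyl to 4-cyanophenyl on a carbonyl carbon

The source may report more compounds than this note shows. Statements on the series, on what has been measured and on what is new or still open speak of the compounds shown alone.

Three compounds have been taken through the growth test so far, and only one of them gave a number. In a functional assay on OCI-Ly3 cells (Homo sapiens) for inhibition, read by CellTiter-Glo, with stated times of 48 h and 96 h (a higher number here means a weaker inhibitor of growth, a lower number a stronger inhibitor of growth), compound 1 (`CCC(=O)[C@H](CCCNC(=N)N)NC(=O)[C@@H]1CCCN1C(=O)[C@@H](NC(=O)[C@H](CC(C)C)NC(=O)OCc1ccccc1)C(C)C`) gives > 20000 nM as a limit of the assay and not a number. In this assay compound 2 (`CC(C)[C@H](NC(=O)OCc1ccccc1)C(=O)N1CCC[C@H]1C(=O)N(C)[C@@H](CCCNC(=N)N)C(=O)CF`) has the entry "not determined" (no result reported) and adds nothing to the comparison. In this assay, for the measured compounds named here, compound 3 (`CC(C)[C@H](NC(=O)c1ccccc1Br)C(=O)N1CCC[C@H]1C(=O)N[C@@H](CCCNC(=N)N)C(=O)CF`) gives 4240 nM as the only actual number in the set.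

Compound 4 (`CC(C)[C@H](NC(=O)c1ccc(C#N)cc1)C(=O)N1CCC[C@H]1C(=O)N[C@@H](CCCNC(=N)N)C(=O)CF`) has yet to be measured. It carries 4-cyanophenyl in place of the 2-bromophenyl of compound 3 on a carbonyl carbon (4-cyanophenyl in place of 2-bromophenyl on a carbonyl carbon). Going by the values given here, no measured pair speaks to this change, so no step beyond the scatter is expected in this assay and neither direction is favoured. The estimated step of a 1.2-fold higher number from compound 3 to compound 4 (0.07 log units; within the scatter) is expected to stay small. The expectation therefore rests on compound 3 at 4240 nM as its sole anchor. Compound 4 is estimated at 5000 nM with 1500 nM to 18000 nM as the expected range.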

Compound 4, concentration for 50% growth inhibition: 6660 nM
Compound 4: the middle estimate sits 1.3-fold (0.12 log units) below what was measured; the range from low to high includes it.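

For the compounds shown here, replacing 2-bromophenyl with 4-cyanophenyl on a carbonyl carbon gives, in this assay, a 1.6-fold higher number from compound 3 to compound 4 (0.20 log units; within the scatter), the first step in the set that can be read between two measured compounds. For this one pair, the exchange leaves growth inhibition unresolved from no change, even though the entering group brings a nitrile and a hydrogen-bond acceptor that the leaving group lacks. No measured property shown here bears on this result.

The compounds shown do not tell how this position would respond to an amine or a carboxylic acid on the phenyl ring, or to a longer alkyl chain in its place. A single pair also cannot separate the exchange of bromine for nitrile from the change in where the substituent sits on the ring.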